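Methoxy in place of fluoro: what compound 4 might give

The source may report more compounds than this note shows. Statements on the series, on what has been measured and on what is new or still open speak of the compounds shown alone.

Of the compounds shown here, three built on one shared core have been tested in a functional assay on SK-BR-3 cells (Homo sapiens) for antiproliferative activity, read by MTT assay, with a stated time of 72 h; a higher number here means a weaker inhibitor, a lower number a stronger inhibitor. Compound 1 `CCN1CCN(c2cc(C)c3cc(NC(=O)c4ccc(F)cc4)ccc3n2)CC1` gives 19800 nM. Compound 3 `CCN1CCN(c2cc(C)c3cc(NC(=O)c4cccc(F)c4)ccc3n2)CC1`, which carries 3-fluorophenyl in place of 4-fluorophenyl on a carbonyl carbon, gives 24900 nM; the step of a 1.3-fold higher number from compound 1 to compound 3 (0.10 log units; within the scatter) lies within the scatter. Compound 2 `CCN1CCN(c2cc(C)c3cc(NC(=O)c4ccc(F)c(F)c4)ccc3n2)CC1` gives 1980 nM, and the step of a 10-fold lower number from compound 1 to compound 2 (1.00 log units; beyond the scatter) is beyond the scatter, as is the step of a 13-fold higher number from compound 2 to compound 3 (1.10 log units; beyond the scatter). Among the three numbers, compound 1 thus stands second highest, indistinguishable from compound 3 and far from compound 2.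

Compound 4 `CCN1CCN(c2cc(C)c3cc(NC(=O)c4ccc(OC)cc4)ccc3n2)CC1` has not yet been measured in this assay. Relative to compound 1 the change is methoxy in place of fluoro on an aromatic carbon. Among the measured compounds shown here, none of the measured steps covers this exchange: the steps seen so far concern only a fluoro added where hydrogen was, or a fluoro moved from one ring carbon to another, and the sole large movement, a 10-fold lower number from compound 1 to compound 2 (1.00 log units; beyond the scatter), came from an added fluoro that compound 4 does not carry. For the measured compounds named here, with no measured step on which to rest, the writer expects no movement beyond the scatter, that is a step of a 1.0-fold higher number from compound 1 to compound 4 (0.00 log units; within the scatter). Compound 4 is therefore estimated at 20000 nM, with a range from 7000 nM to 60000 nM.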

Compound 4, half-maximal inhibitory concentration: 9000 nM
Beside the measured number, compound 4's estimate is 2.2-fold (0.35 log units) above it; low and high end bracket the measured number.
By their numbers in this assay, from the lowest: compound 2; then compound 4; then compounds 1 and 3 (each within the scatter of the next).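

Methoxy in place of fluoro on this aromatic carbon, para to a large group, gives a 2.2-fold lower number from compound 1 to compound 4 (0.34 log units; beyond the scatter) in this assay, so the group at this position can shift the number even when no fluoro remains on the ring. Compound 4 also separates from its other two neighbours, with a 2.8-fold lower number from compound 3 to compound 4 (0.44 log units; beyond the scatter) and with a 4.5-fold higher number from compound 2 to compound 4 (0.66 log units; beyond the scatter) as the two steps that place it in the middle of the series, clear of the pair formed by compound 1 and compound 3 but short of the 3,4-difluorophenyl amide. Nothing available bears on what lies behind these steps.

On these data alone, whether a hydroxy group, an amine or a longer chain such as ethoxy at this same carbon would carry the number further down or back up remains open. As far as these compounds go, it is equally open how methoxy would behave on the ring carbon that holds fluoro in compound 3, and whether methoxy combined with a second group on the ring would come closer to compound 2.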